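Swapping the amide side chain of a coumarin for a phenyl ether

A few compounds are considered here, and "the series" means these few. Any claim that something is new, unique, unknown or untested is made for them only; others in the source may bear on it.

Measured compounds:
- compound 1, `CCOC(=O)COc1cc(=O)oc2cc(OCc3cccc(Cl)c3)ccc12`: 0%
- compound 2, `CN(C)C(=O)COc1cc(=O)oc2cc(OCc3cccc(Cl)c3)ccc12`: 10%

In an assay on isolated protein (strain Sprague-Dawley) for inhibition of Amine oxidase [flavin-containing] A (Rattus norvegicus), read by spectrophotometry, with a stated time of 5 min, tested at 10 uM (a lower number here means less inhibition, a higher number more inhibition at the concentration tested (going by the name of the read-out)), compound 1 gives 0% and compound 2 gives 10%. Among the measured compounds shown here, the only step between them, a number 10 percentage points higher from compound 1 to compound 2 (within the scatter), lies within the scatter, so the two numbers cannot be told apart. Compound 2 stands as the higher of the two numbers, but only nominally.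

Compound 3, `O=c1cc(Oc2ccccc2)c2ccc(OCc3cccc(Cl)c3)cc2o1`, has not yet been measured. Its change from compound 2 is phenyl in place of (dimethylcarbamoyl)methyl on an oxygen on an aromatic ring. For the measured compounds named here, no measured step touches this position; the step from compound 1 to compound 2 changed only the group on the carbonyl carbon, which is removed entirely here. So nothing shown predicts the direction, and both measured numbers sit near the bottom of the scale.

For compound 3 the expected result in this assay is therefore near the measured pair, estimated at 15%, in the range 0% to 45%. The expected step from compound 2 is a number 5 percentage points higher from compound 2 to compound 3 (within the scatter), not clearly beyond the scatter.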

Compound 3, a percentage reported as inhibition, at one concentration (the size of the read-out at that concentration, not a potency): 0%
Beside the measured number, compound 3's estimate is 15 percentage points above it, and the stated range covers the measured number.
By their numbers in this assay, from the lowest: compounds 1, 3 and 2 (each within the scatter of the next).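

In this assay, phenyl in place of (dimethylcarbamoyl)methyl gives a number 10 percentage points lower from compound 2 to compound 3 (within the scatter) and phenyl in place of (ethoxycarbonyl)methyl gives no change at the digits printed from compound 1 to compound 3 (within the scatter) on the same oxygen on an aromatic ring. Among the compounds shown here, the earlier pair compared only two groups on a carbonyl carbon, whereas this result removes that carbonyl chain altogether and puts a six-membered aromatic ring of carbon only in its place. Even so, all three compounds remain within the scatter of one another, so this much larger change gives no measurable separation in this assay. No measurement shown offers an explanation for this result.

Going by these compounds, it remains open whether any group on this oxygen can give a reading clear of the scatter. An amine on a longer chain, a carboxylic acid or a phenyl ring carrying a chlorine could each test that.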